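The source may report more compounds than this note shows. Statements on the series, on what has been measured and on what is new or still open speak of the compounds shown alone.

In a functional assay on Hs 683 cells (Homo sapiens) for cytotoxicity, read by MTT assay, with a stated time of 72 h (a lower number here means a stronger inhibitor, a higher number a weaker inhibitor), compound 1 `N#Cc1sc(N2CCCC2)nc1Cl` is reported as > 100000 nM and this is a limit, not a number. For the measured compounds named here, compound 2 `COC(=O)c1sc2nc(SC)sc2c1C` gives 79000 nM as the only actual number so far. Going by the values given here, compound 3 `COC(=O)c1sc2nc(N3CCCCC3)sc2c1C` shares the core of compound 2 and carries piperidin-1-yl in place of methylsulfanyl on an aromatic carbon as its one change. Among the compounds with values here, no measured step yet shows what such a change does, so no step beyond the scatter is expected in this assay in either direction. For compound 3 the estimated value is 60000 nM with an expected range from 20000 nM to 100000 nM around it. That estimate amounts to a 1.3-fold lower number from compound 2 to compound 3 (0.12 log units; within the scatter) as the expected step.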

Compound 3, half-maximal inhibitory concentration: > 100000 nM
Compound 3 ended at the assay's limit; the forecaster's own chance of this, stated with the estimate: 25%; middle value at least 1.6-fold (0.22 log units) from the limit.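

For the compounds shown here, this is the first measured change at this position, and in this assay piperidin-1-yl in place of methylsulfanyl gives an at least 1.2-fold higher number from compound 2 to compound 3 (0.10 log units; that floor lies within the scatter). Compound 3 gives > 100000 nM, which is a limit and not a number, so the true size of the step cannot be read. The larger group gives no lower number, and most values here offer little to compare: the limit of > 100000 nM in this assay, at which 2 of the 3 values shown sit.

Still open, as far as these compounds go, is whether a small amine at this position would give a real number well below the limit. From the compounds shown here alone, what a carboxylic acid would do in place of the methyl ester also remains open.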